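Swapping the nitrophenyl of compound 1 for fluorophenyl

This account rests on a few compounds, and the source may have more. Where it says the series, first, only, none or still open, it means among the compounds named here.

Compound 1 `O=C(Nc1cccc([N+](=O)[O-])c1)N1CCN(S(=O)(=O)c2sccc2-c2ccccc2Oc2ccc(O)c(O)c2)CC1` is one of three compounds tested in a functional assay on HL-60 cells (Homo sapiens) for inhibition, read by CCK-8 assay, with a stated time of 48 h (a lower number here means a stronger inhibitor, a higher number a weaker inhibitor), where compound 1 gives 4500 nM. That number is the second highest of the three: compound 2 `O=C(NCCNS(=O)(=O)c1ccc(-c2ccccc2OCc2ccccc2)s1)Nc1cc(Cl)cc(Cl)c1` gives 11700 nM, while compound 3 `COc1cccc(NC(=O)NCCNS(=O)(=O)c2ccc(-c3ccccc3OCc3ccccc3)s2)c1` gives 1700 nM. Compound 4 `O=C(Nc1ccc(F)cc1)N1CCN(S(=O)(=O)c2sccc2-c2ccccc2Oc2ccc(O)c(O)c2)CC1` has not yet been measured; it differs from compound 1 in a single place, (4-fluorophenyl in place of 3-nitrophenyl on an amide-type nitrogen). Within the data shown here, the only measured step that also changes the ring on an amide-type nitrogen is a 6.9-fold lower number from compound 2 to compound 3 (0.84 log units; beyond the scatter), and it sits on a different core, so it points to a modest step at most and gives no firm direction. The expected step is therefore small, a 1.3-fold lower number from compound 1 to compound 4 (0.11 log units; within the scatter), and compound 4 is estimated at 3500 nM, within 1200 nM to 10000 nM.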

Compound 4, half-maximal inhibitory concentration: 8100 nM
The estimate for compound 4 lay 2.3-fold (0.36 log units) below the measured number, within the range that was stated.
By their numbers in this assay, from the lowest: compound 3; then compounds 1, 4 and 2 (each within the scatter of the next, the first and the last beyond it).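

In this assay, 4-fluorophenyl in place of 3-nitrophenyl on the amide-type nitrogen gives a 1.8-fold higher number from compound 1 to compound 4 (0.26 log units; within the scatter). On the core of compound 1, then, this change leaves no readable difference, even though the group that leaves carries hydrogen-bond acceptors and the one that enters has none. No measurement shown bears on why this is so.

The group and its place on the ring change together here. 3-fluorophenyl or 4-nitrophenyl would be needed to separate the two. On these data alone, how a carboxylic acid or an amine on this ring would read also remains open.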